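Methoxy addition on the aryl ring of a bis-benzylidene series

This account rests on a few compounds, and the source may have more. Where it says the series, first, only, none or still open, it means among the compounds named here.

Measured so far in a functional assay on SW-620 cells (Homo sapiens) for cytotoxicity, read by MTT assay, with a stated time of 72 h; a lower number here means a stronger inhibitor, a higher number a weaker inhibitor:
compound 1, `COc1ccc(/C=C2\CCC/C(=C\c3cccc(OC)c3OC)C2=O)cc1OC`, gives 6400 nM
compound 2, `COc1cccc(/C=C2\CCC/C(=C\c3ccc(OC)c(OC)c3)C2=O)c1`, gives 3700 nM
compound 3, `COc1ccc(/C=C2\CCC/C(=C\c3ccc(OC)c(OC)c3)C2=O)cc1`, gives 6600 nM

The three sit close together; the step of a 1.7-fold higher number from compound 2 to compound 1 (0.24 log units; within the scatter) and the step of a 1.8-fold higher number from compound 2 to compound 3 (0.25 log units; within the scatter) are both within the scatter, so no ordering among them is claimed.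

Compound 4, `COc1ccc(/C=C2\CCC/C(=C\c3ccc(OC)c(OC)c3)C2=O)c(OC)c1`, is not yet measured. It differs from compound 3 by methoxy in place of hydrogen on an aromatic carbon. Compound 1 differs from compound 2 by methoxy in place of hydrogen on an aromatic carbon, which gave the step of a 1.7-fold higher number from compound 2 to compound 1 (0.24 log units; within the scatter). The two cores differ by 4-methoxyphenyl in place of 3-methoxyphenyl on a double-bonded chain carbon bound to a double-bonded ring carbon. The entering methoxy stands in both cases ortho to a large group, but in compound 4 it is meta to a methoxy group, whereas in compound 1 it is ortho to a methoxy group; the change is therefore the same kind of change, not the same.

Among the compounds with values here, the expected step for compound 4 is a 1.2-fold higher number from compound 3 to compound 4 (0.08 log units; within the scatter), resting on the only measured example of this kind of change, a 1.7-fold higher number from compound 2 to compound 1 (0.24 log units; within the scatter), which stayed within the scatter. Compound 4 is thus estimated at 8000 nM in this assay, with a likely range from 3500 nM to 18000 nM.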

Compound 4, half-maximal inhibitory concentration: > 20000 nM
Compound 4: a limit, no number (the forecaster's own chance of this, stated with the estimate: 5%); at least 2.5-fold (0.39 log units) between middle value and limit.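

In this assay compound 4 gives > 20000 nM, which is a limit of the assay and not a number. Methoxy in place of hydrogen on an aromatic carbon gives an at least 3.0-fold higher number from compound 3 to compound 4 (0.48 log units; beyond the scatter), a step beyond the scatter on this core, whereas the same kind of change gave a 1.7-fold higher number from compound 2 to compound 1 (0.24 log units; within the scatter) on the core of compound 2. This shows that a step within the scatter on one core does not guarantee one on another, but it does not show by how much the two steps differ, and two examples give no rule for the series: the same change on two cores in this assay, a 1.7-fold higher number (0.24 log units; within the scatter) from compound 2 to compound 1 and an at least 3.0-fold higher number (0.48 log units; beyond the scatter) from compound 3 to compound 4; the limit leaves it open whether they differ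

From the compounds shown here alone, the true value of compound 4 remains open, as does whether the step depends on the core or on the place of the entering group, ortho to a large group and meta to a methoxy group. Also open, going by these compounds, is whether a hydroxy group, an amine or a fluorine atom in that same place would give a step like that of methoxy.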